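Trifluoromethyl for methyl on compound 3

The compounds below may be only part of what the source reports. "The series", "measured", "known", "first", "only" and "open" are said of these compounds alone.

Measured in an ADME assay on cells (Hepatocyte, Mus musculus) for metabolic stability; a higher number here means that the compound lasts longer, a lower number that the compound disappears faster:
Compound 1 `CS(=O)(=O)NC1CCC(CN2CCN(c3cc(=O)c4cc(C(F)(F)F)cc([N+](=O)[O-])c4s3)CC2)CC1`: > 1.55 h (a limit)
Compound 2 `O=c1cc(N2CCN(CC3CCC(NS(=O)(=O)c4ccccc4)CC3)CC2)sc2c([N+](=O)[O-])cc(C(F)(F)F)cc12`: > 1.55 h (a limit)
Compound 3 `Cc1ccc(C(=O)OC2CCC(CN3CCN(c4cc(=O)c5cc(C(F)(F)F)cc([N+](=O)[O-])c5s4)CC3)CC2)cc1`: 0.202 h

Of these three compounds, only compound 3 has an actual number, 0.202 h, so it cannot be placed exactly against the other two. Compound 4 `O=C(OC1CCC(CN2CCN(c3cc(=O)c4cc(C(F)(F)F)cc([N+](=O)[O-])c4s3)CC2)CC1)c1ccc(C(F)(F)F)cc1` differs from compound 3 in one place, with trifluoromethyl in place of methyl on an aromatic carbon, para to a large group (trifluoromethyl in place of methyl on an aromatic carbon).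

For the measured compounds named here, no measured step makes this exchange. The closest are an at least 7.6-fold lower number from compound 1 to compound 3 (0.88 log units; beyond the scatter) and an at least 7.6-fold lower number from compound 2 to compound 3 (0.88 log units; beyond the scatter), both beyond the scatter. Each of these replaces the whole group on a saturated ring carbon, whereas compound 4 keeps the carbonyl and the oxygen link of compound 3 and changes only the far end of that group. With so little evidence on this smaller change, the expectation stays close to the measured value of compound 3, 0.202 h, and no shift beyond the scatter is expected. The expected result is a 1.0-fold lower number from compound 3 to compound 4 (0.00 log units; within the scatter). For compound 4 the estimated half-life is 0.2 h, with an expected range from 0.08 h to 0.5 h.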

Compound 4, half-life: 0.278 h
Beside the measured number, compound 4's estimate is 1.4-fold (0.14 log units) below it; low and high end bracket the measured number.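

In this assay, trifluoromethyl in place of methyl on an aromatic carbon, para to a large group, gives a 1.4-fold higher number from compound 3 to compound 4 (0.14 log units; within the scatter). For the compounds shown here, this is the first view of a change at the far end of the group on the saturated ring carbon, with the carbonyl and its oxygen link kept. Here, that small exchange leaves the two compounds within the scatter, unlike the exchange of the whole group in an at least 7.6-fold lower number from compound 1 to compound 3 (0.88 log units; beyond the scatter).

As far as these compounds go, how an amine or a carboxylic acid on this same aromatic carbon would compare remains open, as does the effect of an amide link in place of the oxygen link. Compound 1 and compound 2 each give only a limit, so the step between them cannot be read: the limit of > 1.55 h in this assay, at which 2 of the 4 values shown sit.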